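Trimming the acetamide headgroup: compound 3 to compound 4

A few compounds are considered here, and "the series" means these few. Any claim that something is new, unique, unknown or untested is made for them only; others in the source may bear on it.

Measured compounds:
compound 1 `O=C(Cn1cnc2cccnc21)N1CCN(c2scnc2-c2nc3ccccc3[nH]2)CC1`, 30 nM
compound 2 `Cc1nc(-c2nc3ccccc3[nH]2)c(N2CCN(C(=O)Cn3cnc4cccnc43)[C@H](C)C2)s1`, 9 nM
compound 3 `CCOc1ncc(-c2nc(C(F)(F)F)sc2N2CCN(C(=O)Cn3ccc4cccnc43)[C@H](C)C2)cn1`, 3.8 nM

In a functional assay on CHO-K1 cells for antagonist activity at C-X-C chemokine receptor type 3 (Homo sapiens), read by FLIPR, with a stated time of 10 min (on this read-out lower numbers stand for stronger inhibition and higher numbers for weaker inhibition), compound 3 gives 3.8 nM, the lowest number of the three. Its gap to compound 2 lies beyond the usual scatter, and its gap to compound 1 is wider still, so compound 3 stands as the strongest inhibitor of the measured set. Compound 4 `CCOc1ncc(-c2nc(C(F)(F)F)sc2N2CCN(C(=O)Cn3cc(Cl)cn3)[C@H](C)C2)cn1` keeps the whole of compound 3 apart from the group attached to the saturated chain carbon bound to the carbonyl carbon, where the change is a group of 6 heavy atoms (3 carbon, 2 nitrogen, 1 chlorine; one five-membered aromatic ring with 2 hetero atoms) in place of a group of 9 heavy atoms (7 carbon, 2 nitrogen; one five-membered aromatic ring with 1 hetero atom, one six-membered aromatic ring with 1 hetero atom), on a saturated chain carbon bound to a carbonyl carbon. For the measured compounds named here, no measured pair differs in this single place, so the size of the step cannot be read from the data; the bicyclic group is present in every measured compound, and the effect of losing it is untested. A smaller aromatic group in this position is expected to cost some inhibition, with a step from compound 3 to compound 4 of about a 3.2-fold higher number from compound 3 to compound 4 (0.50 log units; beyond the scatter), beyond the scatter but not large. Compound 4 is therefore estimated at 12 nM, within a range of 4 nM to 40 nM.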

Compound 4, half-maximal inhibitory concentration: 5.1 nM
The estimate for compound 4 lay 2.4-fold (0.37 log units) above the measured number; the measured number falls inside the stated range.
By their numbers in this assay, from the lowest: compounds 3, 4 and 2 (each within the scatter of the next, the first and the last beyond it); then compound 1.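

In this assay, the exchange of the two-ring group for 4-chloro-1H-pyrazol-1-yl, on a saturated chain carbon bound to a carbonyl carbon, gives a 1.3-fold higher number from compound 3 to compound 4 (0.13 log units; within the scatter). For the compounds shown here, no earlier pair varied this place, and this step shows that the two-ring group present in compounds 1, 2 and 3 is not required for inhibition at this level: a single five-membered aromatic ring with a chlorine serves as well, at least on the core of compound 3. The data offer no explanation for this result.

Whether the chlorine itself contributes remains open, since no compound shown has an unsubstituted pyrazole or one carrying a methyl group or a nitrile in its place. Going by these compounds, it is equally open whether the 4-chloro-1H-pyrazol-1-yl group would serve as well on the core of compound 2.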